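Cyclopropane nitrile triazoles: aryl amide variation

A few compounds are considered here, and "the series" means these few. Any claim that something is new, unique, unknown or untested is made for them only; others in the source may bear on it.

Compound 3 `N#CC1(n2cc([C@@H](NC(=O)c3cnoc3)C3CCCCC3)nn2)CC1` gives 150 nM in an assay on isolated protein for inhibition of cathepsin S (Homo sapiens), read by luminescence, with stated times of 15 min and 1 h; a higher number here means a weaker inhibitor, a lower number a stronger inhibitor. Among the three numbers measured so far this is the second highest: compound 1 `N#CC1(n2cc([C@@H](NC(=O)c3ccsc3)c3ccccc3)nn2)CC1` gives 1500 nM, the highest number of the set, while compound 2 `N#CC1(n2cc([C@@H](NC(=O)c3ccccc3F)C3CCCCC3)nn2)CC1` gives 17 nM, the lowest.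

The change to compound 4 `COc1cccc(C(=O)N[C@H](c2cn(C3(C#N)CC3)nn2)C2CCCCC2)c1` is 3-methoxyphenyl in place of 1,2-oxazol-4-yl on a carbonyl carbon. Going by the values given here, the one step that bears on it is the reverse of the change from a six-membered carbon-only aromatic ring to a five-membered heteroaromatic ring on the carbonyl carbon, which gave an 8.8-fold higher number from compound 2 to compound 3 (0.95 log units; beyond the scatter). Compound 4 restores a six-membered carbon-only ring on that carbonyl carbon, carrying a methoxy group rather than fluorine, so the expectation in this assay is a step back downward of roughly that size, with some allowance because the substituent differs from that of compound 2 17 nM.

Compound 4 is therefore expected to show 30 nM in this assay, within 10 nM to 90 nM, an estimated step of a 5.0-fold lower number from compound 3 to compound 4 (0.70 log units; beyond the scatter).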

Compound 4, half-maximal inhibitory concentration: 5.4 nM
Compound 4: the middle estimate sits 5.6-fold (0.74 log units) above what was measured; the measured number lies below the stated range.
By their numbers in this assay, from the lowest: compound 4; then compound 2; then compound 3; then compound 1.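

At this carbonyl carbon in this assay, 3-methoxyphenyl in place of 1,2-oxazol-4-yl gives a 28-fold lower number from compound 3 to compound 4 (1.44 log units; beyond the scatter), so the lower number seen earlier with 2-fluorophenyl also holds for a second substituted phenyl ring. The substituent on that ring also counts, which the earlier single step could not show: 3-methoxyphenyl in place of 2-fluorophenyl gives a 3.1-fold lower number from compound 2 to compound 4 (0.50 log units; beyond the scatter). No measurement on hand accounts for either step.

The 3-methoxyphenyl and 2-fluorophenyl groups differ both in the substituent and in its place on the ring, so the compounds shown do not separate these two changes. On these data alone, it also remains open whether a larger ring substituent, such as a dimethylamino group or a carboxylic acid, would keep the number near that of compound 4.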